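This account rests on a few compounds, and the source may have more. Where it says the series, first, only, none or still open, it means among the compounds named here.

Compound 2, `CC(C)[C@@H](O)CNC(C)(C)CC(=O)N[C@@H]1CCc2ccccc2N(Cc2ccc(-c3ccccc3-c3nn[nH]n3)cc2)C1=O`, is the weaker of the two measured compounds in a functional assay (Pituitary gland cell) with Rattus norvegicus as the target (a lower number here means that less compound is needed, a higher number that more compound is needed for the effect), where compound 2 gives 200 nM. For the measured compounds named here, its only measured neighbour is compound 1, `CC(C)(O)CNC(C)(C)CC(=O)N[C@@H]1CCc2ccccc2N(Cc2ccc(-c3ccccc3-c3nn[nH]n3)cc2)C1=O`, for which this assay records 10 nM; the step of a 20-fold higher number from compound 1 to compound 2 (1.30 log units; beyond the scatter) is the sole comparison available. Compound 3, `CC(C)(CC(=O)N[C@@H]1CCc2ccccc2N(Cc2ccc(-c3ccccc3-c3nn[nH]n3)cc2)C1=O)NC[C@H](O)[C@@H](O)CO`, has not been measured in this assay. Going by the values given here, it differs from compound 2 by the change (1,2-dihydroxyethyl in place of isopropyl on a saturated chain carbon bound to an oxygen on a saturated carbon and a saturated chain carbon), a modification that sits on the same chain, bound to the amine nitrogen, as the single measured step. That step shows that this part of the molecule is sensitive: swapping one small group on this chain for another shifted the number far beyond the scatter. Among the compounds with values here, it does not show in which direction a change from isopropyl to 1,2-dihydroxyethyl would move the number, since only one step is known and it involves a different pair of groups. Compound 3 is therefore expected to lie somewhere near compound 2, with a wide margin in either direction, and the estimated step of a 1.3-fold lower number from compound 2 to compound 3 (0.12 log units; within the scatter) is taken as small. The estimate for compound 3 in this assay is 150 nM, with a range from 30 nM to 800 nM.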

Compound 3, concentration for half-maximal effect: 40 nM
For compound 3 the middle estimate is 3.8-fold (0.57 log units) above the measured one, and the stated range covers the measured number.
By their numbers in this assay, from the lowest: compound 1; then compound 3; then compound 2.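

In this assay, 1,2-dihydroxyethyl in place of isopropyl gives a 5.0-fold lower number from compound 2 to compound 3 (0.70 log units; beyond the scatter), so the earlier finding that this chain is sensitive now has a direction for this particular change: the number falls rather than rises. The second comparison sets a limit on that gain, since 1,2,3-trihydroxypropyl in place of 1-hydroxy-1-methylethyl gives a 4.0-fold higher number from compound 1 to compound 3 (0.60 log units; beyond the scatter), which leaves compound 1 with the lowest number of the three and compound 3 between the other two. Adding hydroxyl groups to the chain therefore does not by itself give the lowest number, with compound 1 going against any such reading, and nothing available here explains these shifts.

The compounds shown leave open whether the gain seen for compound 3 depends on the defined stereocentre of its 1,2-dihydroxyethyl group or would persist with the opposite configuration at that carbon. They also leave open how the number would respond if a methoxy group, an amine or a carboxylic acid stood at the end of this chain in place of the hydroxyl groups.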